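The compounds below may be only part of what the source reports. "The series", "measured", "known", "first", "only" and "open" are said of these compounds alone.

Measured so far:

Compound 1, `Cc1cc(O)c(C(=O)/C=C/c2ccccc2)c(-c2ccc(Br)cc2)c1C(=O)/C=C/c1ccccc1`, gives 10000 nM in a functional assay on MCF7 cells (Homo sapiens) for cytotoxicity, read by MTT assay, with a stated time of 24 h; a higher number here means a weaker inhibitor, a lower number a stronger inhibitor.
Compound 2, `COc1ccc(/C=C/C(=O)c2c(C)cc(O)c(C(=O)/C=C/c3ccc(OC)cc3)c2-c2ccc(Br)cc2)cc1`, is recorded as "not active" (no number reported) in this assay, without a number.
Compound 3, `Cc1cc(O)c(C(=O)/C=C/c2ccc(OCc3ccccc3)cc2)c(-c2ccccc2)c1C(=O)/C=C/c1ccc(OCc2ccccc2)cc1`, gives 10000 nM in this assay.

Among the numbers shown, compound 1 sits level with compound 3: the two values agree at the digits reported, and their gap lies within the usual scatter of this kind of measurement, so neither can be called stronger or weaker than the other. Compound 2 offers no number to compare against, only the note that it did not register as active. Going by the values given here, no pair of measured compounds differs in just one place, so there is no measured single-point step to lean on.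

Compound 4, `Cc1cc(O)c(C(=O)/C=C/c2ccccc2)c(-c2ccc(Cl)cc2)c1C(=O)/C=C/c1ccccc1`, is the unmeasured compound and is reached from compound 1 by a single change: chloro in place of bromo on an aromatic carbon. Nothing in the measured set tests what this exchange does in this assay. Given that compound 1 gives 10000 nM and that no step of this kind has been measured, the expectation for compound 4 is a step of no change at the digits printed from compound 1 to compound 4 (within the scatter), that is, no change beyond the scatter in either direction. Compound 4 is therefore estimated at 10000 nM, with a range from 5000 nM to 20000 nM.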

Compound 4, half-maximal inhibitory concentration: 15000 nM
Compound 4: middle estimate off by 1.5-fold (0.18 log units), on the low side, within the range that was stated.
By their numbers in this assay, from the lowest: compounds 1, 3 and 4 (each within the scatter of the next).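

In this assay, going by these compounds alone, putting chloro in place of bromo gives a 1.5-fold higher number from compound 1 to compound 4 (0.18 log units; within the scatter), and this is the only measured step in the set that changes a single place. Within the data shown here, it shows that the 4-bromophenyl and 4-chlorophenyl versions of the shared core cannot be told apart in this test, something the earlier compounds could not show, as none of them differed in just one place. Among these compounds, the result describes only this exchange of one halogen for another, on an aromatic carbon para to a large group, and no measurement at hand offers an explanation for it.

From the compounds shown here alone, what remains open is how this position responds to a group that is not a halogen at all, such as an amine or a carboxylic acid, or to a smaller halogen such as fluoro. Going by these compounds, it is also open whether chloro in place of bromo would read the same way on a version of the core that carries different side chains, as a single pair of compounds cannot settle that.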